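Swapping Ethynyl for Methoxycarbonyl on the Fused Core

This account rests on a few compounds, and the source may have more. Where it says the series, first, only, none or still open, it means among the compounds named here.

Measured compounds in an assay on isolated protein for inhibition of phosphatidylinositol 4,5-bisphosphate 3-kinase catalytic subunit beta isoform (Homo sapiens), read by 33P incorporation, with a stated time of 60 min; a higher number here means a weaker inhibitor, a lower number a stronger inhibitor:
- compound 1 `Cc1ccc([N+](=O)[O-])cc1S(=O)(=O)N(C)/N=C/c1cnn2ccccc12` reaches only a limit, > 10000 nM
- compound 2 `CC(=O)Oc1ccn2ncc(/C=N/N(C)S(=O)(=O)c3cc([N+](=O)[O-])ccc3C)c2c1` also reaches only a limit, > 1000 nM
- compound 3 `C#Cc1ccn2ncc(/C=N/N(C)S(=O)(=O)c3cc([N+](=O)[O-])ccc3C)c2c1` gives 30 nM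

Going by the values given here, compound 3 holds the only real number among the three; the other two values are limits of the assay, namely the limit of > 10000 nM in this assay, at which 1 of the 3 values shown sits, and (the limit of > 1000 nM in this assay, at which 1 of the 3 values shown sits). The change to compound 4 `COC(=O)c1ccn2ncc(/C=N/N(C)S(=O)(=O)c3cc([N+](=O)[O-])ccc3C)c2c1` is methoxycarbonyl in place of ethynyl on an aromatic carbon. Among the compounds with values here, two measured steps bear on it. The step of an at least 330-fold lower number from compound 1 to compound 3 (2.52 log units; beyond the scatter) and the step of an at least 33-fold lower number from compound 2 to compound 3 (1.52 log units; beyond the scatter) both show that the ethynyl group carries the potency, and that an oxygen-bearing substituent at this carbon leaves the number at a limit. Since methoxycarbonyl likewise replaces the ethynyl with an oxygen-bearing group, a large rise in the number is expected for compound 4 in this assay, in the direction of weaker inhibition, with a fair chance that only a limit is reported. Compound 4 is therefore estimated at 1500 nM, within 200 nM to 10000 nM, meaning an expected step of a 50-fold higher number from compound 3 to compound 4 (1.70 log units; beyond the scatter).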

Compound 4, half-maximal inhibitory concentration: > 1000 nM
Compound 4 was reported as a limit; the forecaster's own chance of this, stated with the estimate: 40%; the middle value is on the limit's open side.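

In this assay, the step of an at least 33-fold higher number from compound 3 to compound 4 (1.52 log units; beyond the scatter) shows that the potency seen with ethynyl at this carbon is not kept by methoxycarbonyl. Methoxycarbonyl is joined to the ring through carbon, whereas the acetoxy group of compound 2 is joined through oxygen, so the earlier loss is now seen with both kinds of attachment. Compound 4 ends at a limit, the same one as compound 2: the limit of > 1000 nM in this assay, at which 2 of the 4 values shown sit.

The steps from compound 1 and from compound 2 to compound 4 cannot be read, so these compounds do not show whether methoxycarbonyl differs from hydrogen or acetoxy at this carbon. As far as these compounds go, it also stays open whether the triple bond itself matters, which a nitrile, a vinyl group or a longer propynyl chain at this carbon could test.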